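Ester to acid on the para-substituted series

A few compounds are considered here, and "the series" means these few. Any claim that something is new, unique, unknown or untested is made for them only; others in the source may bear on it.

Measured so far:
Compound 1, `CCCCCCCCc1ccc(OCC(=O)Cn2nnc(-c3cccc(C(=O)OC)c3)n2)cc1`: 34 nM
Compound 2, `CCCCCCCCc1ccc(OCC(=O)Cn2nnc(-c3cccc(C(=O)O)c3)n2)cc1`: 36 nM
Compound 3, `CCCCCCCCc1ccc(OC(C)C(=O)Cn2nnc(-c3ccc(C(=O)OC)cc3)n2)cc1`: 25 nM

All three were tested in an assay on microsomes from brain for inhibition of Fatty-acid amide hydrolase 1 (Rattus norvegicus), read by fluorescence and HPLC, with a stated time of 60 min; a higher number here means a weaker inhibitor, a lower number a stronger inhibitor. Compound 1 and compound 2 differ by one change, (hydrogen in place of methyl on an oxygen next to a carbonyl group), and this gave a 1.1-fold higher number from compound 1 to compound 2 (0.02 log units; within the scatter). Compound 3 has a different core; how the core of compound 3 differs from the core of compound 1 is not broken down here. Compound 4, `CCCCCCCCc1ccc(OC(C)C(=O)Cn2nnc(-c3ccc(C(=O)O)cc3)n2)cc1`, has not yet been measured. It differs from compound 3 by hydrogen in place of methyl on an oxygen next to a carbonyl group, which is the same change as that from compound 1 to compound 2, at the same kind of place. Because a 1.1-fold higher number from compound 1 to compound 2 (0.02 log units; within the scatter) stayed within the scatter, the step of a 1.1-fold higher number from compound 3 to compound 4 (0.03 log units; within the scatter) is expected to be small as well. Compound 4 is therefore estimated at about 27 nM in this assay, with a range from 13 nM to 55 nM.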

Compound 4, half-maximal inhibitory concentration: 50 nM
Estimate against measurement, compound 4: 1.9-fold (0.27 log units) below; low and high end bracket the measured number.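

In this assay, going from methoxycarbonyl to carboxy gave a 2.0-fold higher number from compound 3 to compound 4 (0.30 log units; within the scatter). Set beside the earlier step, the same change carries from one core to the other with no difference that can be told from the scatter: the same change on two cores in this assay, a 1.1-fold higher number (0.02 log units; within the scatter) from compound 1 to compound 2 and a 2.0-fold higher number (0.30 log units; within the scatter) from compound 3 to compound 4, 1.9-fold (0.28 log units) apart, within the scatter of two such steps. This shows only that, on these two cores, putting hydrogen in place of methyl on that oxygen leaves the number within the scatter; two pairs cannot show that this holds on other cores, nor rule out a small real difference between these two.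

The compounds shown leave open what an amide or a nitrile in place of the carboxy group would give. They also leave open whether a longer chain would alter this step.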